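The source may hold more compounds than are shown below. What is called first, only, known or untested is meant among the compounds shown, and "the series" means these compounds.

In a functional assay on MCF7 cells (Homo sapiens) for antiproliferative activity, with a stated time of 5 days (on this read-out higher numbers stand for weaker inhibition and lower numbers for stronger inhibition), compound 1 (`COc1ccc(-c2[nH]c3ccc(OC)cc3c2C=O)cc1`) gives 180 nM and compound 2 (`COc1ccc(-c2[nH]c3ccc(CC(C)C)cc3c2C=O)cc1`) gives 180 nM on the same read-out. Going by the values given here, compound 2 thus stands level with compound 1, its only measured neighbour. The next structure is compound 3 (`COc1ccc(-c2[nH]c3ccc(C(C)(C)C)cc3c2C=O)cc1`), which carries tert-butyl in place of isobutyl on an aromatic carbon. The two have the same atoms, joined differently, and neither group has a ring or a net charge. Among the compounds with values here, only one measured step bears on this change, the exchange at the same aromatic carbon that leads to compound 2 (no change at the digits printed from compound 1 to compound 2 (within the scatter)). That step, with isobutyl in place of methoxy, stayed within the scatter. Within the data shown here, it is a single step, and no compound with tert-butyl has been measured, so the evidence is thin. A step beyond the scatter is therefore not expected in this assay, and no direction can be favoured. The expected step is small (no change at the digits printed from compound 2 to compound 3 (within the scatter)) and carries a wide margin. Compound 3 is expected at 180 nM with an estimated range from 60 nM to 550 nM in this measurement.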

Compound 3, half-maximal inhibitory concentration: 580 nM
Estimate against measurement, compound 3: 3.2-fold (0.51 log units) below; the whole stated range lies below it.
By their numbers in this assay, from the lowest: compounds 1 and 2 (each within the scatter of the next); then compound 3.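

The new value shows that this aromatic carbon of the shared core does not accept every group alike in this assay: replacing isobutyl with tert-butyl gives (a 3.2-fold higher number from compound 2 to compound 3 (0.51 log units; beyond the scatter)), even though the two groups have the same atoms, joined differently. Until now the only step at this carbon, the exchange of methoxy for isobutyl, had shown no separation between its compounds (no change at the digits printed from compound 1 to compound 2 (within the scatter)), and the direct exchange of methoxy for tert-butyl now gives a step beyond the scatter (a 3.2-fold higher number from compound 1 to compound 3 (0.51 log units; beyond the scatter)). So at this position the way the four carbons are joined separates two otherwise matching groups, though nothing at hand gives a measured reason for this difference.

As far as these compounds go, how an amine, a carboxylic acid, a longer chain such as n-hexyl or a ring such as cyclohexyl would read at this aromatic carbon remains open. Also open, from the compounds shown here alone, is whether tert-butyl would give a step of similar size if another part of the shared core were changed, since these three compounds differ only at this one position.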